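Trading a flexible aryl ether chain for a direct pyridine ring

This account rests on a few compounds, and the source may have more. Where it says the series, first, only, none or still open, it means among the compounds named here.

Compound 1 `Nc1nc(N2CCN(C(=O)COc3ccc(Cl)cc3)CC2)c2nc(CCOc3ccc(F)cc3)sc2n1` gives 3540 nM in a functional assay on cells (Lymphocyte, Homo sapiens) (on this read-out higher numbers stand for weaker inhibition and lower numbers for stronger inhibition), the highest of the three numbers measured, with compound 3 `Nc1nc(N2CCN(C(=O)COc3ccc(Br)cc3)CC2)c2nc(-c3ccc(F)cc3)sc2n1` nearest at 380 nM and compound 2 `Nc1nc(N2CCN(C(=O)COc3ccc(F)cc3)CC2)c2nc(-c3ccc(F)cc3)sc2n1` furthest at 70 nM. Compound 4 `Nc1nc(N2CCN(C(=O)COc3ccc(Cl)cc3)CC2)c2nc(-c3cccnc3)sc2n1` arises from compound 1 by a single change: pyridin-3-yl in place of 2-(4-fluorophenoxy)ethyl on an aromatic carbon. Within the data shown here, no measured step covers exactly this change; the only step, a 5.4-fold higher number from compound 2 to compound 3 (0.73 log units; beyond the scatter), alters the amide-side ring instead. Still, compounds 2 and 3 both carry an aromatic ring joined directly to the shared core and sit far lower than compound 1, so a sizeable drop is expected for compound 4, with a 14-fold lower number from compound 1 to compound 4 (1.15 log units; beyond the scatter). Compound 4 is therefore estimated at 250 nM, within a range from 60 nM to 1000 nM.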

Compound 4, half-maximal inhibitory concentration: 50 nM
For compound 4 the middle estimate is 5.0-fold (0.70 log units) above the measured one, outside the stated range (below it).
By their numbers in this assay, from the lowest: compounds 4 and 2 (each within the scatter of the next); then compound 3; then compound 1.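

With the amide side held as in compound 1, changing only the group on this aromatic carbon of the five-membered ring gives a 71-fold lower number from compound 1 to compound 4 (1.85 log units; beyond the scatter) in this assay. Among these compounds, the earlier step, a 5.4-fold higher number from compound 2 to compound 3 (0.73 log units; beyond the scatter), concerned only the amide-side ring, so this is the first direct sign that this position alone can shift the number strongly. No measurement shown explains the drop.

This single swap both removes the 2-(4-fluorophenoxy)ethyl chain and brings in a ring nitrogen, so the contribution of each remains unresolved. Pyridin-4-yl or plain phenyl at this carbon, with the amide side unchanged, would help separate them.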